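The source may report more compounds than this note shows. Statements on the series, on what has been measured and on what is new or still open speak of the compounds shown alone.

The measured compounds:
Compound 1, `COc1ccc(Br)cc1CCc1c(F)cccc1C(=O)/N=C(\N)NCCCCN(C)Cc1ccccc1`, which in a functional assay for antagonist activity at Melanocortin receptor 4 (Homo sapiens), read by cAMP accumulation (on this read-out higher numbers stand for weaker inhibition and lower numbers for stronger inhibition), gives 180 nM.
Compound 2, `COc1ccc(Br)cc1CCc1c(F)cccc1C(=O)/N=C(\N)NCC(C)C`, which in this assay gives 8500 nM.

Among the measured compounds shown here, compound 2 stands highest of the two numbers in this assay, with compound 1 as its only neighbour. The step of a 47-fold higher number from compound 1 to compound 2 (1.67 log units; beyond the scatter) lies beyond the scatter.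

Compound 3, `COc1ccc(Br)cc1CCc1c(F)cccc1C(=O)/N=C(\N)NCCCN1CCN(C)CC1`, has not yet been measured. It differs from compound 2 by 2-(4-methylpiperazin-1-yl)ethyl in place of isopropyl on a saturated chain carbon bound to an amine nitrogen. For the measured compounds named here, only one measured step bears on this change: exchanging 3-(benzyl(methyl)amino)propyl for isopropyl on a saturated chain carbon bound to an amine nitrogen produced a 47-fold higher number from compound 1 to compound 2 (1.67 log units; beyond the scatter), a large rise. Compound 3 moves in the opposite direction, replacing the isopropyl with a longer chain that ends in a six-membered non-aromatic ring. Going by the values given here, the new chain is not the one found in compound 1, so the reversal need not be complete, but the same part of the molecule is restored to a similar length. A large fall in this assay is therefore expected from compound 2 to compound 3, a 21-fold lower number from compound 2 to compound 3 (1.33 log units; beyond the scatter). The estimate for compound 3 in this assay is 400 nM, within 120 nM to 1500 nM.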

Compound 3, half-maximal inhibitory concentration: 670 nM
The estimate for compound 3 lay 1.7-fold (0.22 log units) below the measured number, and the stated range covers the measured number.
By their numbers in this assay, from the lowest: compound 1; then compound 3; then compound 2.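

In this assay, among the compounds shown here, the fall from the isopropyl end shows that the large change seen earlier is not tied to the single chain of compound 1: putting 2-(4-methylpiperazin-1-yl)ethyl in place of isopropyl gives a 13-fold lower number from compound 2 to compound 3 (1.10 log units; beyond the scatter) and so recovers much of the strength of inhibition at this saturated chain carbon bound to an amine nitrogen. The recovery is only partial, and the end of the chain still counts, since 4-methylpiperazin-1-yl in place of (benzyl(methyl)amino)methyl gives a 3.7-fold higher number from compound 1 to compound 3 (0.57 log units; beyond the scatter) on the same core, a modest step but one beyond the scatter. Nothing measured here explains either step.

The compounds shown leave open whether length alone accounts for the fall, which a plain hexyl chain carrying no nitrogen would test, since both long chains here contain amine nitrogens. They also leave open whether the modest gap between the two chain ends follows the benzyl group or the piperazine ring, which a chain ending in a dimethylamine or a morpholine could help to separate.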